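A few compounds are considered here, and "the series" means these few. Any claim that something is new, unique, unknown or untested is made for them only; others in the source may bear on it.

Measured so far in a physicochemical assay for solubility, read by LC-MS, in phosphate buffer, with a stated time of 24 h, at pH 7.4; on this read-out higher numbers stand for higher solubility and lower numbers for lower solubility:
compound 1 `Cn1cc(-c2cnc(NCc3c(F)ccc4c3CCO4)c3cn[nH]c(=O)c23)cn1`: 1000 nM
compound 2 `Cc1nccn1-c1cnc(NCc2c(F)ccc3c2CCO3)c2cn[nH]c(=O)c12`: 7000 nM
compound 3 `Cc1cc(-c2cnc(NCc3c(F)ccc4c3CCO4)c3cn[nH]c(=O)c23)n(C)n1`: 1000 nM

Compound 3 stands level with compound 1, and together the two hold the low end of these three numbers. Compound 2, with its 2-methyl-1H-imidazol-1-yl group, is the one that stands apart, as a 7.0-fold lower number from compound 2 to compound 3 (0.85 log units; beyond the scatter) shows.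

The next compound, compound 4 `CN(c1ccn(C)n1)c1cnc(NCc2c(F)ccc3c2CCO3)c2cn[nH]c(=O)c12`, has yet to be measured in this assay. It carries methyl(1-methyl-1H-pyrazol-3-yl)amino in place of 1,3-dimethyl-1H-pyrazol-5-yl on an aromatic carbon.

All three measured steps concern this same place on the shared core. The exchange of 1-methyl-1H-pyrazol-4-yl for 1,3-dimethyl-1H-pyrazol-5-yl gave no change at the digits printed from compound 1 to compound 3 (within the scatter), while the exchange of 1-methyl-1H-pyrazol-4-yl for 2-methyl-1H-imidazol-1-yl gave a 7.0-fold higher number from compound 1 to compound 2 (0.85 log units; beyond the scatter). Within the data shown here, no measured compound carries an amino group at this place, and the data therefore offer no direct guide to the new link. Among the measured compounds shown here, the closest precedent is the swap in no change at the digits printed from compound 1 to compound 3 (within the scatter), and on that basis no step beyond the scatter is expected, though an upward move like a 7.0-fold higher number from compound 1 to compound 2 (0.85 log units; beyond the scatter) stays possible. The expected step is a 1.5-fold higher number from compound 3 to compound 4 (0.18 log units; within the scatter). For compound 4 the estimated value is 1500 nM, with an expected range from 350 nM to 7000 nM.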

Compound 4, solubility: 12000 nM
Beside the measured number, compound 4's estimate is 8.0-fold (0.90 log units) below it; the whole stated range lies below it.
By their numbers in this assay, from the lowest: compounds 1 and 3 (each within the scatter of the next); then compounds 2 and 4 (each within the scatter of the next).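

Read in this assay, this place on the shared core gives a large move when methyl(1-methyl-1H-pyrazol-3-yl)amino enters, with a 12-fold higher number from compound 3 to compound 4 (1.08 log units; beyond the scatter) and a 12-fold higher number from compound 1 to compound 4 (1.08 log units; beyond the scatter), so the two pyrazolyl groups of the earlier compounds no longer mark the only level seen with a pyrazole ring here. The imidazolyl group is also no longer alone at the high end: a 1.7-fold higher number from compound 2 to compound 4 (0.23 log units; within the scatter), and two different groups thus share that level within the scatter. Nothing measured alongside these numbers bears on why they moved.

The change from compound 3 to compound 4 alters the link to the core, the methyl group on that link and the way the ring is attached all at once, and the compounds shown do not separate these parts. Still open, from the compounds shown here alone, is how the number would respond to an unsubstituted amine link, to an ether oxygen link, or to a saturated ring such as morpholine or piperidine on the same aromatic carbon.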